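Sulfonamide Variation on a Prostaglandin D2 Receptor Antagonist Series

The compounds below may be only part of what the source reports. "The series", "measured", "known", "first", "only" and "open" are said of these compounds alone.

Compound 1, `Cc1ccc(S(=O)(=O)NC(C)C)cc1C#Cc1cc(Cl)ccc1OCC(=O)O`, gives 3.4 nM.
Compound 2, `Cc1ccc(S(C)(=O)=O)cc1C#Cc1cc(Cl)ccc1OCC(=O)O`, gives 5 nM.
Compound 3, `CCN(CC)S(=O)(=O)c1ccc(C)c(C#Cc2cc(Cl)ccc2OCC(=O)O)c1`, gives 3.4 nM.

All three numbers come from an assay on CHO cells for displacement of a labelled ligand from prostaglandin D2 receptor 2 (Homo sapiens), read by scintillation counting; a lower number here means a stronger inhibitor, a higher number a weaker inhibitor. Compound 3 stands level with compound 1, the two together the lowest of the three numbers; the step of no change at the digits printed from compound 1 to compound 3 (within the scatter) and the step of a 1.5-fold lower number from compound 2 to compound 3 (0.17 log units; within the scatter) both lie within the scatter, as does a 1.5-fold higher number from compound 1 to compound 2 (0.17 log units; within the scatter). Compound 4, `Cc1ccc(S(=O)(=O)N2CCOCC2)cc1C#Cc1cc(Cl)ccc1OCC(=O)O`, has not yet been measured. It differs from compound 3 in one place: morpholin-4-yl in place of diethylamino on a sulfonyl sulfur. The two measured changes on the sulfonyl sulfur, a 1.5-fold higher number from compound 1 to compound 2 (0.17 log units; within the scatter) and no change at the digits printed from compound 1 to compound 3 (within the scatter), bear on this one, and neither left the scatter. Compound 4 is therefore expected to show no step beyond the scatter, a 1.2-fold higher number from compound 3 to compound 4 (0.07 log units; within the scatter), in this assay. The estimate for compound 4 is 4 nM, with a range from 2 nM to 8 nM.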

Compound 4, inhibition constant: 3.6 nM
Compound 4: the middle estimate sits 1.1-fold (0.05 log units) above what was measured; the range from low to high includes it.
By their numbers in this assay, from the lowest: compounds 1, 3, 4 and 2 (each within the scatter of the next).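

Set on the sulfonyl sulfur in place of diethylamino, morpholin-4-yl adds one six-membered non-aromatic ring and one hydrogen-bond acceptor, and in this assay the result is a 1.1-fold higher number from compound 3 to compound 4 (0.02 log units; within the scatter) with no departure from the scatter. The other comparisons agree, with a 1.1-fold higher number from compound 1 to compound 4 (0.02 log units; within the scatter) and a 1.4-fold lower number from compound 2 to compound 4 (0.14 log units; within the scatter) also within the scatter, so this sulfur accepts a ring here as it accepted the open groups. No measurement shown gives a reason for this. The compounds shown leave open whether a piperazine or a phenyl group on the sulfonyl sulfur would also stay within the scatter.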